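The compounds below may be only part of what the source reports. "The series", "measured", "known", "first", "only" and "open" are said of these compounds alone.

Measured so far, in a physicochemical assay, with a stated time of 30 min; a lower number here means a stronger inhibitor, a higher number a weaker inhibitor:

Compound 1 `C/C(=N/N=C1\SCC(=O)N1Cc1ccccc1[N+](=O)[O-])c1cccs1` gives 18100000 nM.
Compound 2 `C/C(=N\N=C1/SCC(=O)N1Cc1cccc(Cl)c1)c1ccccn1` gives 26800000 nM.
Compound 3 `O=C1CS/C(=N\N=C2CCCC2)N1Cc1ccccc1F` gives 12400000 nM.

Compound 2 gives the highest of the three numbers in this assay. Compound 1 is nearest to it, and the gap between compound 2 and compound 1 lies within the usual scatter of such measurements, so no order can be read between them. Compound 3 is furthest, with a lower number, and that gap lies beyond the scatter.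

The next compound, compound 4 `C/C(=N\N=C1/SCC(=O)N1Cc1cccc(Cl)c1)c1cccs1`, differs from compound 2 in one place: thiophen-2-yl in place of pyridin-2-yl on a carbon with a double bond to nitrogen. For the measured compounds named here, no measured pair shows this exact change on its own, so the size of the step is uncertain. Compound 1 also carries thiophen-2-yl at this carbon, and compound 1 gives 18100000 nM, which stands within the scatter of compound 2; the step from compound 2 to compound 4 in this assay is therefore expected to be small, none beyond the scatter, if anything toward a slightly lower number. Compound 4 is expected to give about 20000000 nM in this assay, with a range from 8000000 nM to 50000000 nM. The expected step is a 1.3-fold lower number from compound 2 to compound 4 (0.13 log units; within the scatter).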

Compound 4, half-maximal inhibitory concentration: 20300000 nM
For compound 4 the middle estimate is 1.0-fold (0.01 log units) below the measured one, within the range that was stated.
By their numbers in this assay, from the lowest: compounds 3, 1, 4 and 2 (each within the scatter of the next, the first and the last beyond it).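

In this assay, for the compounds shown here, putting thiophen-2-yl in place of pyridin-2-yl on the carbon with a double bond to nitrogen gives a 1.3-fold lower number from compound 2 to compound 4 (0.12 log units; within the scatter) and, with the rest of the molecule held the same, this is the first direct reading of this change at this position. Going by these compounds alone, the two groups differ in ring size and in their hetero atom, one a six-membered aromatic ring with nitrogen and the other a five-membered aromatic ring with sulfur, yet this pair shows no step that can be told from the scatter. No measurement at hand bears on why these two groups read alike.

On these data alone, what a non-aromatic group at this carbon would do stays open, for example a simple amine, a carboxylic acid or a longer chain. Within the data shown here, it is also open whether any group here can move the number beyond the scatter, since this single pair covers only two aromatic rings.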